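Shorter Alkyl Chain on an Alkyne-Linked Nucleoside

The source may hold more compounds than are shown below. What is called first, only, known or untested is meant among the compounds shown, and "the series" means these compounds.

Of the compounds shown here, three have been measured in an ADME assay on HEL cells (Homo sapiens) for cytotoxicity, with a stated time of 3 days; on this read-out lower numbers stand for higher toxicity in this test and higher numbers for lower toxicity in this test. Compound 3 `CCCCCc1ccc(C#Cc2cc3cn([C@H]4C[C@H](O)[C@@H](CO)O4)c(=O)nc3o2)cc1` gives 470000 nM, the higher of the two numbers in this assay. Compound 2 `CCCCCc1ccc(-c2cc3cn([C@H]4C[C@H](O)[C@@H](CO)O4)c(=O)nc3o2)cn1` gives 100000 nM, a value that lies below that of compound 3 and beyond the usual scatter. Compound 1 `CCCc1ccc(CCc2cc3cn([C@H]4C[C@H](O)[C@@H](CO)O4)c(=O)nc3o2)cc1` gives >= 130000 nM, which is a limit of the assay and not a number, namely (the limit of >= 130000 nM in this assay, at which 1 of the 3 values shown sits). Compound 4 `CCCc1ccc(C#Cc2cc3cn([C@H]4C[C@H](O)[C@@H](CO)O4)c(=O)nc3o2)cc1` has not been measured; it differs from compound 3 by hydrogen in place of ethyl on a saturated chain carbon, three bonds along the chain from an aromatic carbon. No pair of measured compounds shares this change, so the shown values give no direction for it. Compound 4 is expected to give about 400000 nM in this assay, between 150000 nM and 1000000 nM. The step is estimated as a 1.2-fold lower number from compound 3 to compound 4 (0.07 log units; within the scatter), within the scatter.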

Compound 4, minimum cytotoxic concentration: 87000 nM
Compound 4: middle estimate off by 4.6-fold (0.66 log units), on the high side; measured number outside the range, below it.
By their numbers in this assay, from the lowest: compounds 4 and 2 (each within the scatter of the next); then compound 3.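

The change from pentyl to propyl gives a 5.4-fold lower number from compound 3 to compound 4 (0.73 log units; beyond the scatter) in this assay, so this chain position is not neutral for the read-out, at least with the alkyne linker. Within the data shown here, the shorter chain goes with higher toxicity in this test, a direction that the earlier compounds could not show. No measurement shown here accounts for this step. From the compounds shown here alone, whether butyl falls on the same trend remains open, as does whether a longer chain such as heptyl raises the number further. An amine on the chain is equally untested here.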